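A Dichlorophenyl Swap on an Inactive Chalcone Lactam

The compounds below may be only part of what the source reports. "The series", "measured", "known", "first", "only" and "open" are said of these compounds alone.

compound 1, `O=C(COc1ccc(C(=O)/C=C/c2ccc(Br)cc2)cc1)N[C@H]1CCOC1=O`: > 64000 nM
compound 2, `Cc1cc(Cl)ccc1NCC(=O)N[C@H]1CCOC1=O`: > 64000 nM
compound 3, `O=C1OCC[C@@H]1NC(=S)SCCOc1ccc(Cl)cc1`: 50500 nM

In a functional assay on MCF7 cells (Homo sapiens) for antiproliferative activity, read by MTT assay, with a stated time of 72 h (on this read-out lower numbers stand for stronger inhibition and higher numbers for weaker inhibition), compound 1 gives > 64000 nM, which is a limit of the assay rather than a number. Compound 2 also stops at a limit, > 64000 nM. Compound 3 gives a number, 50500 nM. Compound 1 thus stands at the limit of > 64000 nM in this assay, at which 2 of the 3 values shown sit.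

Compound 4, `O=C(COc1ccc(C(=O)/C=C/c2ccc(Cl)cc2Cl)cc1)N[C@H]1CCOC1=O`, differs from compound 1 in one place: 2,4-dichlorophenyl in place of 4-bromophenyl on a double-bonded chain carbon bound to a double-bonded chain carbon. Among the compounds with values here, no measured pair shows this kind of change, so no step can be read from the data. The expected step of an at least 1.0-fold lower number from compound 1 to compound 4 (0.02 log units; that floor lies within the scatter) is none beyond the scatter. Compound 4 is expected to give around 60000 nM, between 20000 nM and 150000 nM, quite possibly again reported only as a limit.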

Compound 4, half-maximal inhibitory concentration: 34400 nM
Compound 4: middle estimate off by 1.7-fold (0.24 log units), on the high side; measured number inside the range.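

Replacing 4-bromophenyl with 2,4-dichlorophenyl on a double-bonded chain carbon bound to a double-bonded chain carbon gives a measured number in this assay on the shared core, with an at least 1.8-fold lower number from compound 1 to compound 4 (0.26 log units; that floor lies within the scatter). The floor of this step does not show a firm gain on its own. Compound 1 is held at a limit of the assay, so the full size of the step cannot be read: the limit of > 64000 nM in this assay, at which 2 of the 4 values shown sit.

Going by these compounds, it remains open whether losing the bromine or adding the second chlorine matters more. On these data alone, the effect of a phenyl ring with a single chlorine, or of an amine on this ring, also remains unknown.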